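Nitro to amino on the phenol of compound 3

A few compounds are considered here, and "the series" means these few. Any claim that something is new, unique, unknown or untested is made for them only; others in the source may bear on it.

- compound 1 `C=C[C@@](C)(/C=C/c1ccc(OC(=O)CCC)cc1)CCC=C(C)C`: 20%
- compound 2 `C=C[C@@](C)(/C=C/c1ccc(OC(=O)CCCCC)cc1)CCC=C(C)C`: 18%
- compound 3 `C=C[C@@](C)(/C=C/c1ccc(O)c([N+](=O)[O-])c1)CCC=C(C)C`: 49%

In a functional assay on MCF7 cells (Homo sapiens) for inhibition, with a stated time of 48 h, tested at 50 uM (on this read-out lower numbers stand for less inhibition of growth and higher numbers for more inhibition of growth at the one concentration tested), compound 3 stands highest of the three at 49%, beyond the scatter from compound 1 and from compound 2. The next change gives compound 4 `C=C[C@@](C)(/C=C/c1ccc(O)c(N)c1)CCC=C(C)C`, with amino in place of nitro on an aromatic carbon, ortho to a hydroxy group (amino in place of nitro on an aromatic carbon). Within the data shown here, the only measured step, a number 2 percentage points lower from compound 1 to compound 2 (within the scatter), lies within the scatter and concerns a saturated chain carbon, so it gives no size for this change. Among the measured compounds shown here, no measured pair tests this swap, and any direction remains tentative. A modest fall is expected, estimated as a number 9 percentage points lower from compound 3 to compound 4 (within the scatter). For compound 4 the estimated value is 40%, with an expected range of 20% to 62%.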

Compound 4, percent growth inhibition at one concentration: 17%
Compound 4: middle estimate off by 23 percentage points, on the high side, outside the stated range (below it).
By their numbers in this assay, from the lowest: compounds 4, 2 and 1 (each within the scatter of the next); then compound 3.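

In this assay, among these compounds, the aromatic carbon ortho to a hydroxy group proves sensitive to its substituent: amino in place of nitro gives a number 32 percentage points lower from compound 3 to compound 4 (beyond the scatter), the first step beyond the scatter. The group at this position can therefore set the level of growth inhibition at the one concentration tested. No measurement available here bears on the reason for this step.

Open, as far as these compounds go, is whether a nitrile, a carboxylic acid or an acetamide at this carbon would match nitro or amino. Also open, from the compounds shown here alone, is how the nitro compound would respond to a methoxy group in place of the hydroxy group.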